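Swapping the Pyridine Substituent: A Carboxy Group Enters

The source may report more compounds than this note shows. Statements on the series, on what has been measured and on what is new or still open speak of the compounds shown alone.

Three measured compounds share one core and differ only in the aromatic group attached to the phenyl ring. In a functional assay on HEK293 cells for agonist activity at Bombesin receptor subtype-3 (Homo sapiens), read by luminescence and calcium flux, with a stated time of 10 min (on this read-out lower numbers stand for an effect already at smaller amounts and higher numbers for an effect only at larger amounts of compound), compound 1 `CCC(C)(C)Cc1c[nH]c(CCc2ccc(-n3ccnn3)cc2)n1` gives 641 nM. Compound 2 `CCC(C)(C)Cc1c[nH]c(CCc2ccc(-n3cccn3)cc2)n1` gives 135 nM in this assay, and compound 3 `CCC(C)(C)Cc1c[nH]c(CCc2ccc(-c3ccc(F)cn3)cc2)n1` gives 66 nM. Compound 3 therefore shows the lowest number of the three, with a 9.7-fold lower number from compound 1 to compound 3 (0.99 log units; beyond the scatter) and a 2.0-fold lower number from compound 2 to compound 3 (0.31 log units; beyond the scatter), while a 4.7-fold lower number from compound 1 to compound 2 (0.68 log units; beyond the scatter) describes the remaining pair.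

Compound 4 `CCC(C)(C)Cc1c[nH]c(CCc2ccc(-c3cccnc3C(=O)O)cc2)n1` has not yet been measured. The change from compound 3 is 2-carboxypyridin-3-yl in place of 5-fluoropyridin-2-yl on an aromatic carbon. All three measured steps concern the same position, and they show that exchanging this aromatic group moves the number by a modest amount in either direction. None of them, however, introduces a carboxy group, so the measured steps give a sense of scale but not of direction for this particular swap. Going by the values given here, no measured compound carries a hydrogen-bond donor at this position. Because compound 2 gives 135 nM and compound 3 gives 66 nM with groups that carry no hydrogen-bond donor, compound 4 is expected to give a higher number than compound 3, with the step estimated as a 9.1-fold higher number from compound 3 to compound 4 (0.96 log units; beyond the scatter). The estimate for compound 4 in this assay is 600 nM, within a range from 100 nM to 5000 nM.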

Compound 4, half-maximal effective concentration: 1260 nM
Beside the measured number, compound 4's estimate is 2.1-fold (0.32 log units) below it, within the range that was stated.
By their numbers in this assay, from the lowest: compound 3; then compound 2; then compounds 1 and 4 (each within the scatter of the next).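

Among the four groups shown at this position, only 2-carboxypyridin-3-yl carries a hydrogen-bond donor, and in this assay it produces the only step here graded as large (a 19-fold higher number from compound 3 to compound 4 (1.28 log units; beyond the scatter)). The same group also stands well apart from the pyrazole, with a 9.3-fold higher number from compound 2 to compound 4 (0.97 log units; beyond the scatter), yet it cannot be told apart from the triazole, with a 2.0-fold higher number from compound 1 to compound 4 (0.29 log units; within the scatter), so a group with a hydrogen-bond donor and a triazole without one end up at a similar level in this assay. The position therefore tolerates some aromatic groups far better than others, but nothing available here explains the rise seen with the carboxy group.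

The step from compound 3 to compound 4 removes the fluorine, adds the carboxy group and changes how the pyridine ring is attached, all in one swap, so the shown compounds cannot separate these three changes. On these data alone, whether a methyl ester or a primary amide in place of the carboxylic acid on the same pyridine would give a similarly high number also remains open.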